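The source may report more compounds than this note shows. Statements on the series, on what has been measured and on what is new or still open speak of the compounds shown alone.

In a functional assay on DU-145 cells (Homo sapiens) for antiproliferative activity, read by MTT assay, with a stated time of 48 h (on this read-out higher numbers stand for weaker inhibition and lower numbers for stronger inhibition), compound 3 `C/C(=C\CC/C(C)=C/CC[C@@H]1[C@@]2(C)CCC(=O)C(C)(C)[C@H]2CC[C@@]1(C)O)CC/C=C(\C)C(=O)OCc1cn(-c2ccccc2C)nn1` gives no number, only a limit: > 150000 nM. Compound 1 `COc1ccccc1-n1cc(COC(=O)/C(C)=C/CC/C(C)=C/CC/C(C)=C/CC[C@@H]2[C@@]3(C)CCC(=O)C(C)(C)[C@H]3CC[C@@]2(C)O)nn1` has methoxy where compound 3 has methyl on an aromatic carbon. Compound 1 also gives only a limit: > 150000 nM. The exchange of methoxy for methyl is therefore a step that the two limits leave unreadable from compound 1 to compound 3. Where compound 3 has the 1-(2-methylphenyl)-1H-1,2,3-triazol-4-yl group, ethynyl stands in compound 2 `C#CCOC(=O)/C(C)=C/CC/C(C)=C/CC/C(C)=C/CC[C@@H]1[C@@]2(C)CCC(=O)C(C)(C)[C@H]2CC[C@@]1(C)O`, which gives 46100 nM. Replacing that ethynyl with the larger group is an at least 3.2-fold higher number from compound 2 to compound 3 (0.51 log units; beyond the scatter).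

The next compound to be tested is compound 4 `C/C(=C\CC/C(C)=C/CC[C@@H]1[C@@]2(C)CCC(=O)C(C)(C)[C@H]2CC[C@@]1(C)O)CC/C=C(\C)C(=O)OCc1cn(-c2ccc(Br)cc2)nn1`. It differs from compound 3 as follows: 4-bromophenyl in place of 2-methylphenyl on an aromatic nitrogen. In short, 4-bromophenyl replaces 2-methylphenyl on an aromatic nitrogen, while the rest of the structure stays the same. For the measured compounds named here, no measured compound carries 4-bromophenyl, and the one measured change on this phenyl group cannot be sized. The closest guide is the limit of > 150000 nM in this assay, at which 2 of the 3 values shown sit. With only that to go on, no step beyond the scatter is expected, and another limit is the most likely report. The expected change is a number no higher from compound 3 to compound 4 (the limit leaves the size open). For compound 4 the estimated value is 150000 nM, within an expected range of 50000 nM to 400000 nM.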

Compound 4, half-maximal inhibitory concentration: > 150000 nM
Compound 4 ended at the assay's limit (the forecaster's own chance of this, stated with the estimate: 65%); the middle value lies on the limit itself.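

In this assay, putting the 1-(4-bromophenyl)-1H-1,2,3-triazol-4-yl group in place of ethynyl gives an at least 3.2-fold higher number from compound 2 to compound 4 (0.51 log units; beyond the scatter), the same minimum size of step as that seen for compound 3. A second substituted phenyl group on the triazole nitrogen therefore also leaves the compound on the weaker side of compound 2, and this change of phenyl substituent brings no measurable value back within the range of the assay. The steps among compound 1, compound 3 and compound 4 cannot be read, as all three report only a limit, and that limit is now the most common result in this small set: the limit of > 150000 nM in this assay, at which 3 of the 4 values shown sit.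

On these data alone, how far compound 1, compound 3 and compound 4 each lie past that limit stays open, so no order among their phenyl groups can be given. As far as these compounds go, it is also open whether an unsubstituted phenyl, a benzyl group, or a phenyl ring carrying an amine or a carboxylic acid would give a measurable value.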